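A few compounds are considered here, and "the series" means these few. Any claim that something is new, unique, unknown or untested is made for them only; others in the source may bear on it.

Within the data shown here, in a functional assay on cells for antagonist activity at C-C chemokine receptor type 4 (Homo sapiens), read by GTPgammaS binding (a lower number here means a stronger inhibitor, a higher number a weaker inhibitor), compound 2 `CCNc1nc(NS(=O)(=O)c2cccc(Cl)c2Cl)c2c(OC)nn(C)c2n1` gives 251 nM, the highest of the two numbers measured so far. Compound 1 `COc1nn(C)c2ncnc(NS(=O)(=O)c3cccc(Cl)c3Cl)c12` gives 63.1 nM in this assay, and the step of a 4.0-fold higher number from compound 1 to compound 2 (0.60 log units; beyond the scatter) is the only one measured. Compound 3 `COc1nn(C)c2nc(NC(C)C)nc(NS(=O)(=O)c3cccc(Cl)c3Cl)c12` differs from compound 2 by methyl in place of hydrogen on a saturated chain carbon bound to a nitrogen on an aromatic ring and a saturated chain carbon. Among the measured compounds shown here, no measured step matches this change; the one known step, from adding the ethylamino group, was modest and in the weakening direction. Adding one more carbon to that same chain is expected to move compound 3 by a 1.2-fold higher number from compound 2 to compound 3 (0.08 log units; within the scatter) at most, within the scatter. Compound 3 is therefore estimated at 300 nM, within 120 nM to 800 nM.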

Compound 3, half-maximal inhibitory concentration: 3160 nM
For compound 3 the middle estimate is 11-fold (1.02 log units) below the measured one, and the stated range ends below it.
By their numbers in this assay, from the lowest: compound 1; then compound 2; then compound 3.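

Adding one methyl to the ethylamino chain, turning it into isopropylamino, gives a 13-fold higher number from compound 2 to compound 3 (1.10 log units; beyond the scatter) and so costs more than the first step suggested. Set against hydrogen on the aromatic carbon, isopropylamino gives a 50-fold higher number from compound 1 to compound 3 (1.70 log units; beyond the scatter) and this is the largest gap among the three compounds. Of the three groups at this position, hydrogen therefore gives the lowest number and isopropylamino the highest.

From the compounds shown here alone, whether a smaller amino group or methylamino would come closer to compound 1 remains open. Nothing available explains the sharp loss from that one methyl.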